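Ring-for-chain swap at the ethoxy position of compound 1

A few compounds are considered here, and "the series" means these few. Any claim that something is new, unique, unknown or untested is made for them only; others in the source may bear on it.

Compound 1 `CCOc1ccc(Cl)c(-c2ccc(OCCCC(=O)O)cc2)c1` gives the lowest number of the three measured compounds in a functional assay on isolated protein for agonist activity at Free fatty acid receptor 1 (Homo sapiens), read by HTRF and inositol phosphate accumulation, with a stated time of 60 min (a higher number here means that more compound is needed for the effect, a lower number that less compound is needed), at 1130 nM. Compound 2 `CCOc1ccc(F)c(-c2ccc(OCCCC(=O)O)cc2)c1` gives 3190 nM in this assay, and compound 3 `O=C(O)CCCOc1ccc(-c2cc(OC(F)(F)F)ccc2F)cc1` gives 4220 nM. The step from a 2.8-fold higher number from compound 1 to compound 2 (0.45 log units; beyond the scatter) is the larger of the two measured steps; the step from a 1.3-fold higher number from compound 2 to compound 3 (0.12 log units; within the scatter) is the smaller one.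

Compound 4 `O=C(O)CCCOc1ccc(-c2cc(-[n+]3ccsc3)ccc2Cl)cc1` differs from compound 1 by a group of 5 heavy atoms (3 carbon, 1 nitrogen, 1 sulfur; one five-membered aromatic ring with 2 hetero atoms) in place of a group of 3 heavy atoms (2 carbon, 1 oxygen; no ring), on an aromatic carbon. The group that enters carries a net charge of plus one, the group that leaves is neutral.

Neither measured step covers this change. Within the data shown here, the step from compound 2 to compound 3 touches the same position, replacing the ethyl on the oxygen, and it stayed within the scatter; it is the only step that bears on the position at all. Among the measured compounds shown here, no measured step replaces the ethoxy with a ring or with a charged group, so there is no direct precedent for the size of this change. A step from compound 1 to compound 4 in this assay is therefore expected to be modest and somewhat toward a higher number, a 1.8-fold higher number from compound 1 to compound 4 (0.25 log units; within the scatter), with a wide range. For compound 4 the value is expected to lie near 2000 nM, between 700 nM and 6000 nM.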

Compound 4, half-maximal effective concentration: > 9950 nM
Compound 4 ended at the assay's limit; the forecaster's own chance of this, stated with the estimate: 15%; middle value at least 4.9-fold (0.69 log units) from the limit.
By their numbers in this assay, from the lowest: compound 1; then compounds 2 and 3 (each within the scatter of the next). At a limit, above all of these: compound 4.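

In this assay, the five-membered aromatic ring with 2 hetero atoms and net charge +1 in place of ethoxy gives an at least 8.8-fold higher number from compound 1 to compound 4 (0.94 log units; beyond the scatter). Among these compounds, the only earlier change at this position, on the oxygen, gave a 1.3-fold higher number from compound 2 to compound 3 (0.12 log units; within the scatter), so the aromatic carbon meta to the large group now shows a step beyond the scatter. Compound 4 reads > 9950 nM, which is a limit of the assay and not a number, so the full size of the step stays unknown: the limit of > 9950 nM in this assay, at which 1 of the 4 values shown sits.

The compounds shown leave open which part of the change carries the step, since ring, larger group, loss of the oxygen and net charge all arrive together in compound 4, and no compound separates them. A thiophene ring with no charge, a morpholine or a longer chain such as propoxy on the same aromatic carbon, with the chloro group kept, would show whether the ring alone is enough to give a step of this size or whether the position accepts a larger group at all.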